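A few compounds are considered here, and "the series" means these few. Any claim that something is new, unique, unknown or untested is made for them only; others in the source may bear on it.

The measured compounds: compound 1 `Cc1cc(NC(=O)Cn2cc(-c3ccccc3Cl)nn2)no1` and compound 2 `Cc1csc(NC(=O)Cn2cc(-c3cccs3)nn2)n1`.

In a functional assay on BMDM cells (Mus musculus, strain C57BL/6) for inhibition, with a stated time of 2 days (a lower number here means a stronger inhibitor, a higher number a weaker inhibitor), compound 2 gives 40 nM. For compound 1 only a limit is recorded in this assay, namely > 30000 nM. Compound 2 therefore holds the only number shown; the other value is a limit. Compound 3 `Cc1cc(NC(=O)Cn2cc(-c3cccs3)nn2)no1` has not been measured; it differs from compound 2 in a single place: 5-methyl-1,2-oxazol-3-yl in place of 4-methyl-1,3-thiazol-2-yl on an amide-type nitrogen. Going by the values given here, no step between two measured compounds isolates this change, so its size is not known directly. Compound 1 also bears 5-methyl-1,2-oxazol-3-yl on an amide-type nitrogen and sits only at the limit of > 30000 nM in this assay, at which 1 of the 2 values shown sits, which makes a loss of potency the more likely direction. The step from compound 2 to compound 3 is therefore expected to be a clear weakening, a 38-fold higher number from compound 2 to compound 3 (1.57 log units; beyond the scatter), larger than the scatter. Compound 3 is expected to give 1500 nM in this assay, within a broad range from 150 nM to 30000 nM.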

Compound 3, half-maximal inhibitory concentration: > 30000 nM
Compound 3: only a limit was reported; the forecaster's own chance of this, stated with the estimate: 30%; middle value at least 20-fold (1.30 log units) from the limit.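

With thiophen-2-yl held constant, placing 5-methyl-1,2-oxazol-3-yl instead of 4-methyl-1,3-thiazol-2-yl on the amide-type nitrogen gives an at least 750-fold higher number from compound 2 to compound 3 (2.87 log units; beyond the scatter) in this assay, so this single change, which the earlier compounds could not isolate, is now shown to matter greatly. For compound 3, > 30000 nM is a limit and not a number. Compound 1 and compound 3 both carry only a limit, so the step between them cannot be read and the exchange of 2-chlorophenyl for thiophen-2-yl shows nothing here: the limit of > 30000 nM in this assay, at which 2 of the 3 values shown sit.

From the compounds shown here alone, whether the methyl group of 4-methyl-1,3-thiazol-2-yl contributes remains open, as does how an unsubstituted 1,3-thiazol-2-yl or a pyridin-2-yl on the amide-type nitrogen would compare. Going by these compounds, it is also open how 2-chlorophenyl behaves alongside 4-methyl-1,3-thiazol-2-yl.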